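The source may hold more compounds than are shown below. What is called first, only, known or untested is meant among the compounds shown, and "the series" means these compounds.

Compound 3 `Cc1cc(S(=O)(=O)/N=C(\N)n2nccc2-c2ccccc2)c(SCc2ccccc2C)cc1Cl` stands second highest of the three numbers in a functional assay on HCT-116 cells (Homo sapiens) for cytotoxicity, read by MTT assay, with a stated time of 72 h (on this read-out lower numbers stand for stronger inhibition and higher numbers for weaker inhibition), where compound 3 gives 16000 nM. Compound 1 `Cc1cc(S(=O)(=O)/N=C(\N)n2nccc2-c2ccccc2)c(SCc2ccc(Cl)cc2)cc1Cl` gives 7000 nM, and compound 2 `Cc1cc(-c2ccccc2)n(/C(N)=N/S(=O)(=O)c2cc(C)c(Cl)cc2SCc2ccccc2C)n1` gives 42000 nM. Compound 4 `Cc1ccc(CSc2cc(Cl)c(C)cc2S(=O)(=O)/N=C(\N)n2nccc2-c2ccccc2)cc1` differs from compound 3 by 4-methylphenyl in place of 2-methylphenyl on a saturated chain carbon bound to a sulfur. Of the two measured steps, only a 2.3-fold higher number from compound 1 to compound 3 (0.36 log units; beyond the scatter) concerns the same saturated chain carbon bound to a sulfur; the other, a 2.6-fold lower number from compound 2 to compound 3 (0.42 log units; beyond the scatter), alters a different place and does not bear on this change. Because a 2.3-fold higher number from compound 1 to compound 3 (0.36 log units; beyond the scatter) rose when 2-methylphenyl replaced 4-chlorophenyl, compound 4 is expected to move modestly back toward a lower number, a 1.6-fold lower number from compound 3 to compound 4 (0.20 log units; within the scatter). Compound 4 is therefore estimated at 10000 nM, with a range from 4000 nM to 25000 nM.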

Compound 4, half-maximal inhibitory concentration: 14000 nM
Beside the measured number, compound 4's estimate is 1.4-fold (0.15 log units) below it, within the range that was stated.
By their numbers in this assay, from the lowest: compounds 1, 4 and 3 (each within the scatter of the next, the first and the last beyond it); then compound 2.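

Moving the methyl from 2-methylphenyl to 4-methylphenyl on the saturated chain carbon bound to a sulfur gives a 1.1-fold lower number from compound 3 to compound 4 (0.06 log units; within the scatter), so this shift of the methyl leaves the number unchanged within the scatter. Methyl in place of chloro on an aromatic carbon of the 4-substituted ring gives a 2.0-fold higher number from compound 1 to compound 4 (0.30 log units; within the scatter), so that exchange also stays within the scatter. Nothing available accounts for these small steps.

As far as these compounds go, the effect of an amine or a carboxylic acid on this ring remains open. So does that of a longer chain in place of the saturated chain carbon bound to a sulfur.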